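Methylating a second hydroxyl in a bicyclic lactone series

The source may hold more compounds than are shown below. What is called first, only, known or untested is meant among the compounds shown, and "the series" means these compounds.

Measured so far:
Compound 1 `CO[C@@H]1[C@H]2OC(=O)C[C@H]2O[C@@H]1[C@@H](O)c1ccccc1`: 12700 nM
Compound 2 `O=C1C[C@H]2O[C@H]([C@H](O)c3ccccc3)[C@H](O)[C@H]2O1`: 16600 nM
Compound 3 `CO[C@@H]1[C@H]2OC(=O)C[C@H]2O[C@@H]1[C@H](O)c1ccccc1`: 4040 nM

These three compounds were tested in a functional assay on MCF7 cells (Homo sapiens) for inhibition, read by MTT assay, with a stated time of 72 h; a higher number here means a weaker inhibitor, a lower number a stronger inhibitor. Compound 2 shows the highest number of the three; compound 1 sits close to it, within the scatter, while compound 3 stands clearly lower, a 4.1-fold lower number from compound 2 to compound 3 (0.61 log units; beyond the scatter). The shared core is the same throughout; compound 2 carries a hydroxy group at the position where compounds 1 and 3 carry a methoxy group. Compounds 1 and 3 differ only in the configuration as drawn, and that alone gave a 3.1-fold lower number from compound 1 to compound 3 (0.50 log units; beyond the scatter) (the fact that compounds 1 and 3 differ only in the configuration as drawn).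

Compound 4 `CO[C@H](c1ccccc1)[C@H]1O[C@@H]2CC(=O)O[C@@H]2[C@H]1O` has not yet been measured. It differs from compound 2 by methyl in place of hydrogen on an oxygen on a saturated carbon. The methyl enters on an oxygen on a saturated carbon whose other neighbour is a saturated chain carbon, so it is the same kind of change as from compound 2 to compound 3, but on a different oxygen. The step from compound 2 to compound 3 was modest and lowered the number beyond the scatter. Placing a methyl on the other oxygen is expected to move the number in the same direction, though with less confidence. Compound 4 is therefore expected to give 8000 nM, between 3000 nM and 22000 nM, a step of a 2.1-fold lower number from compound 2 to compound 4 (0.32 log units; beyond the scatter).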

Compound 4, half-maximal inhibitory concentration: > 100000 nM
Compound 4: a limit, no number; the forecaster's own chance of this, stated with the estimate: 5%; middle value at least 12-fold (1.09 log units) from the limit.
By their numbers in this assay, from the lowest: compound 3; then compounds 1 and 2 (each within the scatter of the next). At a limit, above all of these: compound 4.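

In this assay, compound 4 gives > 100000 nM, which is a limit of the assay and not a number. Moving from a hydroxy to a methoxy group at this position gives an at least 6.0-fold higher number from compound 2 to compound 4 (0.77 log units; beyond the scatter), the opposite direction to the lower number seen when the same methyl enters on the other oxygen in compound 3, so the effect of this small change depends on which oxygen receives it. On these data alone, this hydroxy group therefore cannot be methylated with the same result as the other one, and the full size of the loss remains unknown because the reading rests on a limit: the limit of > 100000 nM in this assay, at which 1 of the 4 values shown sits.

The compounds shown do not reveal whether the hydrogen on this oxygen is what matters or whether the added methyl itself is the problem, nor why the two oxygens differ. They also leave open how an ethyl or acetyl group on this oxygen, or an amine in place of the hydroxy group, would read in this assay, and whether the opposite drawn configuration at this carbon would give the same result.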